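Hydroxyalkyl and aryl carbonyl substituents on the ring nitrogen

A few compounds are considered here, and "the series" means these few. Any claim that something is new, unique, unknown or untested is made for them only; others in the source may bear on it.

Measured compounds in an assay on isolated protein for binding affinity to adenosine receptor A1 (Bos taurus); on this read-out higher numbers stand for weaker inhibition and lower numbers for stronger inhibition:
Compound 1 `CCNc1nc(-c2ccccc2)nc2c1nnn2Cc1ccccc1Cl` gives 463000000 nM in this assay.
Compound 2 `OCCCNc1nc(-c2ccccc2)nc2c1nnn2Cc1ccccc1Cl` gives 33000000 nM in this assay.
Compound 3 `COc1ccc(C(=O)Nc2nc(-c3ccccc3)nc3c2nnn3Cc2ccccc2Cl)cc1` gives 20000000 nM in this assay.

Compound 3 has the lowest of the three numbers; its nearest neighbour is compound 2, the step between them, a 1.7-fold lower number from compound 2 to compound 3 (0.22 log units; within the scatter), lying within the scatter, while compound 1 stands furthest away, at a 23-fold lower number from compound 1 to compound 3 (1.36 log units; beyond the scatter). Compound 4 `OCCNc1nc(-c2ccccc2)nc2c1nnn2Cc1ccccc1Cl` is not yet measured. The change from compound 3 to compound 4 is 2-hydroxyethyl in place of (4-methoxyphenyl)carbonyl on a nitrogen on an aromatic ring. Going by the values given here, two measured steps bear on it: a 23-fold lower number from compound 1 to compound 3 (1.36 log units; beyond the scatter) shows that the aryl carbonyl gives a much lower number than ethyl, and a 1.7-fold lower number from compound 2 to compound 3 (0.22 log units; within the scatter) shows that the aryl carbonyl and 3-hydroxypropyl are indistinguishable. The 2-hydroxyethyl group entering is shorter than 3-hydroxypropyl, and the step of a 14-fold lower number from compound 1 to compound 2 (1.15 log units; beyond the scatter) shows that a hydroxyl-bearing chain alone brings a large drop from ethyl. Compound 4 is therefore expected to land between compound 1 and compound 2, a modest rise, estimated as a 3.0-fold higher number from compound 3 to compound 4 (0.48 log units; beyond the scatter). The estimate for compound 4 is 60000000 nM, with a range from 15000000 nM to 250000000 nM.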

Compound 4, inhibition constant: 116000000 nM
Compound 4: the middle estimate sits 1.9-fold (0.29 log units) below what was measured, within the range that was stated.
By their numbers in this assay, from the lowest: compounds 3 and 2 (each within the scatter of the next); then compound 4; then compound 1.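

In this assay, the hydroxyl-bearing chains on this nitrogen are not interchangeable: going to the shorter 2-hydroxyethyl gives a 3.5-fold higher number from compound 2 to compound 4 (0.55 log units; beyond the scatter) and so lies beyond the scatter. Hydroxy on the ethyl chain still counts, with a 4.0-fold lower number from compound 1 to compound 4 (0.60 log units; beyond the scatter) as its step, but that drop is smaller than a 14-fold lower number from compound 1 to compound 2 (1.15 log units; beyond the scatter) seen with 3-hydroxypropyl. The (4-methoxyphenyl)carbonyl group, which could not be told apart from 3-hydroxypropyl, is clearly separated from 2-hydroxyethyl, with a 5.8-fold higher number from compound 3 to compound 4 (0.76 log units; beyond the scatter) as the step.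

No evidence shown accounts for these differences. As far as these compounds go, whether a longer chain such as 4-hydroxybutyl would lower the number further, and whether an amine or a carboxylic acid in place of the hydroxy would keep the drop from ethyl, remains open.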